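Pyrrol-2-yl in place of 4-fluorophenyl on the shared core

This account rests on a few compounds, and the source may have more. Where it says the series, first, only, none or still open, it means among the compounds named here.

Compound 1 `CC1=CC[C@H](C(C)(C)NC(=S)N/N=C/c2ccc(N(C)C)cc2)CC1`: in a functional assay on NCI-H460 cells (Homo sapiens) for inhibition, read by sulforhodamine B assay, with a stated time of 48 h (on this read-out higher numbers stand for weaker inhibition of growth and lower numbers for stronger inhibition of growth), compound 1 gives only a limit of the assay, > 100000 nM.
Compound 2 `CC1=CC[C@H](C(C)(C)NC(=S)N/N=C/c2ccc(F)cc2)CC1`: compound 2 gives only a limit, > 100000 nM.
Compound 3 `CC1=CC[C@H](C(C)(C)NC(=S)N/N=C/c2cccc([N+](=O)[O-])c2)CC1`: compound 3 gives only a limit, > 100000 nM.

Within the data shown here, compound 2 therefore stands nowhere that can be read as a number: its value is a limit, and the two other measured compounds sit at the same limit, so no compound in the set is distinguished from another. Among the measured compounds shown here, the one step between compounds that differ in a single place, a step that the two limits leave unreadable from compound 1 to compound 2, cannot be sized because both of its ends rest on (the limit of > 100000 nM in this assay, at which 3 of the 3 values shown sit).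

Compound 4 `CC1=CC[C@H](C(C)(C)NC(=S)N/N=C/c2ccc[nH]2)CC1` is not yet measured. It differs from compound 2 by 1H-pyrrol-2-yl in place of 4-fluorophenyl on a carbon with a double bond to nitrogen. For the measured compounds named here, no measured step bears readably on this exchange; the only step available is the unreadable one from compound 1 to compound 2. The step of a number no higher from compound 2 to compound 4 (the limit leaves the size open) is therefore expected to stay within the scatter, with the estimate resting on a set that has given limits only. Compound 4 is estimated at 100000 nM, within 30000 nM to 300000 nM, most likely again reported as a limit.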

Compound 4, concentration for total growth inhibition: 57500 nM
Beside the measured number, compound 4's estimate is 1.7-fold (0.24 log units) above it; measured number inside the range.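

In this assay compound 4 gives 57500 nM, the first number in this set that is not a limit, so 1H-pyrrol-2-yl on this carbon is the first group shown to give a readable value. As far as these compounds go, the change gives an at least 1.7-fold lower number from compound 2 to compound 4 (0.24 log units; that floor lies within the scatter), so its true size remains unknown and the part that can be read does not go beyond the scatter. Compound 2 gives only a limit, and that limit remains the main reference point for the set: the limit of > 100000 nM in this assay, at which 3 of the 4 values shown sit.

From the compounds shown here alone, whether the readable value goes with the five-membered ring or with the hydrogen-bond donor that 1H-pyrrol-2-yl brings stays open. A furyl group in the same place, a five-membered aromatic ring with an oxygen atom in its ring, would help to separate the two.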